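Swapping a Nitrile on the Side Chain

The source may report more compounds than this note shows. Statements on the series, on what has been measured and on what is new or still open speak of the compounds shown alone.

Of the compounds shown here, two have so far been measured in a functional assay on HepG2 cells (Homo sapiens) for cytotoxicity, read by sulforhodamine B assay, with a stated time of 48 h; on this read-out higher numbers stand for weaker inhibition and lower numbers for stronger inhibition. Compound 1 `Cc1ccc(-c2nc3ccccc3n2CC(=O)N/N=C/c2ccccc2Cl)o1` gives 22600 nM. Among the compounds with values here, compound 2 `N#CCn1c(-c2ccco2)nc2ccccc21` gives 88100 nM, the highest of the two numbers; compound 1, its only neighbour, sits lower by a gap beyond the usual scatter. Compound 3 `N=C(Cn1c(-c2ccco2)nc2ccccc21)NN` is not yet measured and differs from compound 2 by a group of 4 heavy atoms (1 carbon, 3 nitrogen; no ring) in place of a group of 2 heavy atoms (1 carbon, 1 nitrogen; no ring), on a saturated chain carbon bound to an aromatic nitrogen. Within the data shown here, no measured pair shows this change, so its effect is unknown; a modest shift, possibly within the scatter, is expected in this assay. Compound 3 is estimated at 60000 nM, between 20000 nM and 150000 nM. The expected step is a 1.5-fold lower number from compound 2 to compound 3 (0.17 log units; within the scatter).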

Compound 3, half-maximal inhibitory concentration: 74500 nM
Beside the measured number, compound 3's estimate is 1.2-fold (0.09 log units) below it; the measured number falls inside the stated range.
By their numbers in this assay, from the lowest: compound 1; then compounds 3 and 2 (each within the scatter of the next).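

Within the data shown here, this is the first pair that differs in one place, and it gives a direct reading of this position in this assay: replacing cyano with the group of 4 heavy atoms, on a saturated chain carbon bound to an aromatic nitrogen, gives a 1.2-fold lower number from compound 2 to compound 3 (0.07 log units; within the scatter). The number therefore shows no real response to this change, and no available evidence explains the result. As far as these compounds go, whether an amine, a carboxylic acid or a longer chain at this place would shift the number beyond the scatter remains open.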